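This account rests on a few compounds, and the source may have more. Where it says the series, first, only, none or still open, it means among the compounds named here.

Measured in a functional assay on MGC-803 cells (Homo sapiens) for inhibition, read by sulforhodamine B assay (on this read-out lower numbers stand for stronger inhibition and higher numbers for weaker inhibition), each value being a limit of the assay:
- Compound 1 `O=C1C(NC2CCCC2)=CC(=O)c2c1nc1n2[C@H]2OC[C@@H](O)[C@H]2OC1`: > 16000 nM
- Compound 2 `O=C1C(N2CCCC2)=CC(=O)c2c1nc1n2[C@H]2OC[C@@H](O)[C@H]2OC1`: > 16000 nM
- Compound 3 `CCCN(CCC)C1=CC(=O)c2c(nc3n2[C@H]2OC[C@@H](O)[C@H]2OC3)C1=O`: > 16000 nM

Compound 3 gives no number and shares (the limit of > 16000 nM in this assay, at which 3 of the 3 values shown sit). Compound 4 `O=C1C(Nc2cccc(Cl)c2)=CC(=O)c2c1nc1n2[C@H]2OC[C@@H](O)[C@H]2OC1` keeps the shared core and changes one group: (3-chlorophenyl)amino in place of dipropylamino on a double-bonded ring carbon. Among the compounds with values here, the new group brings a six-membered aromatic ring of carbon only, which none of the measured compounds carries at this place.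

Within the data shown here, three measured steps bear on the change: a step that the two limits leave unreadable from compound 1 to compound 2, a step that the two limits leave unreadable from compound 1 to compound 3 and a step that the two limits leave unreadable from compound 2 to compound 3. None of them has a size that can be carried over, so the expectation rests on little. Any readable change in this assay can only be expected toward stronger inhibition, since all three measured compounds sit at the limit, and a further limit remains quite possible.

The expected change is an at least 1.4-fold lower number from compound 3 to compound 4 (0.16 log units; that floor lies within the scatter). For compound 4 the estimate is 11000 nM, with an expected range from 3000 nM to 32000 nM.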

Compound 4, half-maximal inhibitory concentration: 1530 nM
For compound 4 the middle estimate is 7.2-fold (0.86 log units) above the measured one, outside the stated range (below it).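

In this assay, this double-bonded ring carbon of the shared core now yields a readable value: (3-chlorophenyl)amino in place of dipropylamino gives an at least 10-fold lower number from compound 3 to compound 4 (1.01 log units; beyond the scatter). The same group in place of pyrrolidin-1-yl gives an at least 10-fold lower number from compound 2 to compound 4 (1.01 log units; beyond the scatter). The comparison with the cyclopentylamino compound is the closest, since the amine nitrogen and its hydrogen stay and 3-chlorophenyl in place of cyclopentyl gives an at least 10-fold lower number from compound 1 to compound 4 (1.01 log units; beyond the scatter), so that hydrogen alone does not bring a readable value.

On these data alone, these steps give only a lower bound on size, and the steps among the three earlier compounds cannot be read: the limit of > 16000 nM in this assay, at which 3 of the 4 values shown sit. What a phenylamino group without the chlorine or a benzylamino group would give at this place stays open.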